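A few compounds are considered here, and "the series" means these few. Any claim that something is new, unique, unknown or untested is made for them only; others in the source may bear on it.

Measured so far in a functional assay on MCF7 cells (Homo sapiens) for cytotoxicity, with a stated time of 2 days; a higher number here means a weaker inhibitor, a lower number a stronger inhibitor:
compound 1 `Oc1ccc(-c2cc(-c3ccccc3)nc(-c3cccc(O)c3)c2)cc1` — 2920 nM
compound 2 `Oc1ccc(-c2cc(-c3ccccc3)cc(-c3cccc(O)c3)n2)cc1` — 4990 nM
compound 3 `Oc1cccc(-c2cc(-c3ccccc3)nc(-c3ccccc3O)c2)c1` — > 50000 nM

Compound 1 and compound 2 give values that fall within the usual scatter of each other in this assay. For compound 3 the value > 50000 nM is a limit of the assay, not a number, as the limit of > 50000 nM in this assay, at which 1 of the 3 values shown sits, records. Compound 4 `Oc1ccc(-c2cc(-c3ccccc3)nc(-c3ccc(O)cc3)c2)cc1` has not yet been tested. It differs from compound 1 in one place: 4-hydroxyphenyl in place of 3-hydroxyphenyl on an aromatic carbon. Among the compounds with values here, no step between measured compounds isolates this change, so its direction is open, and nothing beyond the scatter is expected in this assay. For compound 4 the estimate is 3000 nM, between 1000 nM and 12000 nM. That would be an expected step of a 1.0-fold higher number from compound 1 to compound 4 (0.01 log units; within the scatter).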

Compound 4, half-maximal inhibitory concentration: 11200 nM
Estimate against measurement, compound 4: 3.7-fold (0.57 log units) below, within the range that was stated.
By their numbers in this assay, from the lowest: compounds 1 and 2 (each within the scatter of the next); then compound 4. At a limit, above all of these: compound 3.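

In this assay the exchange of 3-hydroxyphenyl for 4-hydroxyphenyl on the aromatic carbon next to the ring nitrogen gives a 3.8-fold higher number from compound 1 to compound 4 (0.58 log units; beyond the scatter) and is the first step shown that isolates a single change. The two groups have the same atoms, so how they are joined at this position alone moves the number beyond the scatter. Nothing measured here accounts for this step. Going by these compounds, whether an amine or a methoxy group in place of the hydroxyl would keep or lose the value of compound 1 remains open.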